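Changing the Phenyl Group on a Low-Nanomolar Compound

The source may report more compounds than this note shows. Statements on the series, on what has been measured and on what is new or still open speak of the compounds shown alone.

In a functional assay on CCRF-CEM cells (Homo sapiens) for antiproliferative activity (on this read-out lower numbers stand for stronger inhibition and higher numbers for weaker inhibition), compound 3 `COc1cc(C(=O)c2sc(-c3cccc([N+](=O)[O-])c3)cc2N)cc(OC)c1OC` gives the lowest of three numbers at 5.9 nM and so shows the strongest inhibition. Compound 1 `COc1ccc(-c2cc(N)c(C(=O)c3cc(OC)c(OC)c(OC)c3)s2)cc1OC` stands at 20 nM and compound 2 `COc1cc(C(=O)c2sc(-c3ccc([N+](=O)[O-])cc3)cc2N)cc(OC)c1OC` at 99 nM on the same scale. Compound 4 `COc1cc(C(=O)c2sc(-c3ccccc3Cl)cc2N)cc(OC)c1OC` carries 2-chlorophenyl in place of 3-nitrophenyl on the same aromatic carbon (2-chlorophenyl in place of 3-nitrophenyl on an aromatic carbon). Within the data shown here, three measured steps changed only this group: one modest (a 3.4-fold lower number from compound 1 to compound 3 (0.53 log units; beyond the scatter)), another modest (a 5.0-fold higher number from compound 1 to compound 2 (0.69 log units; beyond the scatter)) and one large (a 17-fold lower number from compound 2 to compound 3 (1.22 log units; beyond the scatter)). None of them involves 2-chlorophenyl. With compound 3 at 5.9 nM a rise looks likelier than a fall. The expected change is a modest rise (a 6.8-fold higher number from compound 3 to compound 4 (0.83 log units; beyond the scatter)). In this assay compound 4 is estimated at 40 nM (expected range 8 nM to 250 nM).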

Compound 4, half-maximal inhibitory concentration: 16 nM
For compound 4 the middle estimate is 2.5-fold (0.40 log units) above the measured one; measured number inside the range.
By their numbers in this assay, from the lowest: compound 3; then compounds 4 and 1 (each within the scatter of the next); then compound 2.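

Swapping in 2-chlorophenyl, which has no hydrogen-bond acceptors, costs only a modest amount against the best compound here (a 2.7-fold higher number from compound 3 to compound 4 (0.43 log units; beyond the scatter)) and still beats 4-nitrophenyl (a 6.2-fold lower number from compound 2 to compound 4 (0.79 log units; beyond the scatter)). It cannot be told apart from 3,4-dimethoxyphenyl (a 1.3-fold lower number from compound 1 to compound 4 (0.10 log units; within the scatter)), so quite different phenyl groups can give similar numbers at this position. Nothing measured here explains these differences.

Still open, going by these compounds, is whether the chlorine would read the same elsewhere on the phenyl ring. On these data alone, how an amine or a carboxylic acid on that ring would read also remains unknown.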